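One flipped stereocentre: what to expect of compound 3

The compounds below may be only part of what the source reports. "The series", "measured", "known", "first", "only" and "open" are said of these compounds alone.

Compound 1 (`CC(C)C[C@@H]1NC(=O)[C@@H]([C@H](OCc2ccccc2)c2ccccc2)NC(=O)[C@@H](Cc2ccccc2)NC(=O)[C@@H](CC(C)C)NC(=O)[C@H](C(C)C)N(C)C1=O`): 3200 nM
Compound 2 (`CC(C)C[C@@H]1NC(=O)[C@H]([C@@H](OCc2ccccc2)c2ccccc2)NC(=O)[C@@H](Cc2ccccc2)NC(=O)[C@@H](CC(C)C)NC(=O)[C@H](C(C)C)N(C)C1=O`): 5800 nM

Both values come from a functional assay on HCT-116 cells (Homo sapiens) for cytotoxicity, read by hypoxanthine incorporation, with a stated time of 72 h; a lower number here means a stronger inhibitor, a higher number a weaker inhibitor. Among the compounds with values here, compound 2 lies within the scatter of compound 1, the only other compound measured so far, so neither can be ranked above the other. The gap between them rests on (the fact that compounds 1 and 2 differ only in the configuration as drawn), meaning that the same atoms and bonds are arranged differently in space.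

The next compound is compound 3 (`CC(C)C[C@@H]1NC(=O)[C@@H]([C@@H](OCc2ccccc2)c2ccccc2)NC(=O)[C@@H](Cc2ccccc2)NC(=O)[C@@H](CC(C)C)NC(=O)[C@H](C(C)C)N(C)C1=O`), and the change from compound 2 is small: the two compounds have the same atoms and bonds and differ only in configuration as drawn: 1 of 6 stereo elements differ; a stereocentre at a saturated ring carbon is drawn S in compound 2 and R in compound 3. Nothing leaves and nothing enters. Within the data shown here, the one measured step, a 1.8-fold higher number from compound 1 to compound 2 (0.26 log units; within the scatter), reversed a stereocentre at a saturated ring carbon and a stereocentre at a saturated chain carbon together. On the strength of that step, no change beyond the scatter is expected in this assay for this single reversal, although a single reversal has not been tested alone.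

For compound 3 the expected value is 4500 nM, with an estimated range from 1500 nM to 14000 nM.

That estimate means an expected 1.3-fold lower number from compound 2 to compound 3 (0.11 log units; within the scatter), a step of no real size.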

Compound 3, half-maximal inhibitory concentration: 8900 nM
For compound 3 the middle estimate is 2.0-fold (0.30 log units) below the measured one, and the stated range covers the measured number.
By their numbers in this assay, from the lowest: compounds 1, 2 and 3 (each within the scatter of the next, the first and the last beyond it).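

The two single reversals can now be read apart, and they do not look alike. In this assay, reversing only the stereocentre at the saturated ring carbon gives a 1.5-fold higher number from compound 2 to compound 3 (0.19 log units; within the scatter), so this change cannot be told from the noise of repeated measurement. Reversing only the stereocentre at the saturated chain carbon gives a 2.8-fold higher number from compound 1 to compound 3 (0.44 log units; beyond the scatter), a modest step, but the first in this small set to clear the scatter, and nothing other than the spatial arrangement can account for it: the fact that compounds 1 and 3 differ only in the configuration as drawn

Three arrangements of these two stereocentres are shown, so it remains open how the fourth, with the ring carbon drawn S and the chain carbon drawn R, would read in this assay. As far as these compounds go, it also remains open whether the chain carbon would still matter if the benzyl ether on it gave way to a free hydroxyl or an amine, since all three compounds carry the same ether and differ only in how it is held in space.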